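Indole-nitrogen substituent on a fused nitrile core

The source may report more compounds than this note shows. Statements on the series, on what has been measured and on what is new or still open speak of the compounds shown alone.

Measured compounds:
compound 1 `N#Cc1c(-c2ccc3c(ccn3CC3CC3)c2)ccn2c(CC(F)(F)F)cnc12` — 190 nM
compound 2 `Cn1ccc2cc(-c3ccn4c(CC(F)(F)F)cnc4c3C#N)ccc21` — 230 nM

In a functional assay on CHO cells for agonist activity at metabotropic glutamate receptor 2 (Homo sapiens), read by GTPgammaS binding (on this read-out lower numbers stand for an effect already at smaller amounts and higher numbers for an effect only at larger amounts of compound), compound 2 gives 230 nM, the higher of the two numbers, but the step of a 1.2-fold higher number from compound 1 to compound 2 (0.08 log units; within the scatter) lies within the scatter, so the two compounds are not told apart. Compound 3 `N#Cc1c(-c2ccc3c(ccn3C3CCOCC3)c2)ccn2c(CC(F)(F)F)cnc12` differs from compound 2 by oxan-4-yl in place of methyl on an aromatic nitrogen. Among the measured compounds shown here, the only step at this position, a 1.2-fold higher number from compound 1 to compound 2 (0.08 log units; within the scatter), shows that exchanging the group on this nitrogen left the number essentially unchanged, so no step beyond the scatter is expected here either. Compound 3 is therefore estimated at 250 nM, between 100 nM and 650 nM, a step of a 1.1-fold higher number from compound 2 to compound 3 (0.04 log units; within the scatter) from compound 2.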

Compound 3, half-maximal effective concentration: 501 nM
Beside the measured number, compound 3's estimate is 2.0-fold (0.30 log units) below it, and the stated range covers the measured number.
By their numbers in this assay, from the lowest: compounds 1 and 2 (each within the scatter of the next); then compound 3.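

In this assay this aromatic nitrogen no longer looks indifferent to its group: oxan-4-yl gives a 2.2-fold higher number from compound 2 to compound 3 (0.34 log units; beyond the scatter) and a 2.6-fold higher number from compound 1 to compound 3 (0.42 log units; beyond the scatter), whereas methyl and cyclopropylmethyl could not be told apart. Among the compounds shown here, the first steps beyond the scatter at this position therefore come with a six-membered non-aromatic ring bearing one oxygen, and both are modest. Nothing available bears on the origin of these steps.

From the compounds shown here alone, whether the higher number goes with the ring or with its oxygen stays open; cyclohexyl on this nitrogen would separate the two. Going by these compounds, how an amine such as piperidin-4-yl or a longer chain would read here is also open.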